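Swapping Fluoro for Chloro: From Compound 3 to Compound 4

The compounds below may be only part of what the source reports. "The series", "measured", "known", "first", "only" and "open" are said of these compounds alone.

Three members of this series have been measured in an assay on cells for inhibition of HSP60/HSP10 (Homo sapiens), with a stated time of 60 min; on this read-out higher numbers stand for weaker inhibition and lower numbers for stronger inhibition. For the measured compounds named here, compound 1 `O=S(=O)(Nc1ccc(-c2nc3ccccc3o2)cc1)c1ccc(Cl)c(C(F)(F)F)c1` gives 12000 nM in this assay, the only value in the set that is a number rather than a limit. Compound 2 `C=Cc1ccc(S(=O)(=O)Nc2ccc3oc(-c4ccccc4)nc3c2)cc1` reaches only the limit of > 100000 nM. Compound 3 `O=S(=O)(Nc1ccc2oc(-c3ccccc3)nc2c1)c1cccc(F)c1` likewise ends at the limit of > 100000 nM. The step that the two limits leave unreadable from compound 2 to compound 3 cannot be read, since both of its ends rest at the limit of > 100000 nM in this assay, at which 2 of the 3 values shown sit.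

Compound 4 `O=S(=O)(Nc1ccc2oc(-c3ccccc3)nc2c1)c1cccc(Cl)c1` is the member still to be tested. It differs from compound 3 by chloro in place of fluoro on an aromatic carbon. Going by the values given here, the only measured step that touches the ring on the sulfonyl sulfur, the one between compound 2 and compound 3, gives no readable size, so the measured data say nothing about how a change on that ring moves the read-out. Compound 3 stands at the limit, and compound 4 is expected to stand close to the same place. The step is expected to be a number no higher from compound 3 to compound 4 (the limit leaves the size open), within the scatter. Compound 4 is therefore estimated at 100000 nM in this assay, with a range from 30000 nM to 300000 nM, and will most likely again be reported as a limit.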

Compound 4, half-maximal inhibitory concentration: > 100000 nM
Compound 4 was reported as a limit; the forecaster's own chance of this, stated with the estimate: 70%; the middle value lies on the limit itself.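

Compound 4 ends at a limit in this assay, as do compound 2 and compound 3, so no new step can be read from compound 4 to either of them: the limit of > 100000 nM in this assay, at which 3 of the 4 values shown sit. The compounds shown leave open whether 3-chlorophenyl and 3-fluorophenyl on the sulfonyl sulfur differ at all on this read-out.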